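Difluoromethyl in Place of Chloro: Expecting Compound 3

The source may hold more compounds than are shown below. What is called first, only, known or untested is meant among the compounds shown, and "the series" means these compounds.

Compound 1, `NS(=O)(=O)NCCCNC(=O)/C(=N/O)Nc1ccc(F)c(Cl)c1`: 1200 nM
Compound 2, `O=C(Nc1ccc(Cl)cc1)C(=O)N1CCC(c2ccnc3ccc(F)cc23)CC1`: 15 nM

In an assay on SK-OV-3 cells for inhibition of Indoleamine 2,3-dioxygenase 1 (Homo sapiens) (a higher number here means a weaker inhibitor, a lower number a stronger inhibitor), compound 1 gives 1200 nM. In this assay compound 2 gives 15 nM, the lower of the two numbers, and its gap to compound 1 lies well beyond the scatter. Compound 3, `O=C(Nc1ccc(C(F)F)cc1)C(=O)N1CCC(c2ccnc3ccc(F)cc23)CC1`, is compound 2 with one change: difluoromethyl in place of chloro on an aromatic carbon. Among the compounds with values here, no pair of measured compounds shows this exchange, so nothing in the data fixes its size. The expectation is a small step, from compound 2 to compound 3 of a 1.7-fold higher number from compound 2 to compound 3 (0.22 log units; within the scatter), toward a slightly higher number but possibly no further than the scatter reaches. For compound 3 the estimated value in this assay is 25 nM, with a range from 8 nM to 80 nM, and this estimate rests only on the result of compound 2, 15 nM.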

Compound 3, half-maximal inhibitory concentration: 21 nM
Estimate against measurement, compound 3: 1.2-fold (0.08 log units) above; the measured number falls inside the stated range.
By their numbers in this assay, from the lowest: compounds 2 and 3 (each within the scatter of the next); then compound 1.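

Within the data shown here, this exchange gives the only reading at this position: in this assay, going from 4-chlorophenyl to 4-(difluoromethyl)phenyl gives a 1.4-fold higher number from compound 2 to compound 3 (0.15 log units; within the scatter), so the two compounds cannot be ordered. On this aromatic carbon, para to a large group, three heavy atoms can therefore stand in place of a single chlorine with no change that can be told from the scatter. The data at hand offer no explanation for this result.

From the compounds shown here alone, whether the same position accepts an unsubstituted carbon, a methyl, a trifluoromethyl, a nitrile, an amine or a carboxylic acid remains open. Among these compounds, it is also open whether chloro and difluoromethyl would read alike on any core other than the one shared by compound 2 and compound 3.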